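A Trimethoxyphenyl Amide Built on an Unreadable Starting Point

The source may report more compounds than this note shows. Statements on the series, on what has been measured and on what is new or still open speak of the compounds shown alone.

Compound 2 `O=C(Nc1ccccc1)c1csc(-c2cn(Cc3ccc(Cl)cc3)c3ccccc23)n1` is tested in a functional assay on PC-3 cells (Homo sapiens) for cytotoxicity, read by MTT assay, with a stated time of 48 h, in the presence of a further agent that is not named here; on this read-out higher numbers stand for weaker inhibition and lower numbers for stronger inhibition. In that test compound 2 gives > 100000 nM, which is a limit of the assay and not a number. Compound 1 `COc1ccc(NC(=O)c2csc(-c3cn(Cc4ccc(Cl)cc4)c4ccccc34)n2)cc1`, carrying a methoxy group on an aromatic carbon, also reaches only a limit with > 100000 nM. Compound 3 `O=C(Nc1ccccc1)c1csc(-c2c[nH]c3ccccc23)n1`, bearing hydrogen on the aromatic nitrogen, likewise stops at a limit with > 100000 nM. The step that the two limits leave unreadable from compound 1 to compound 2 and the step that the two limits leave unreadable from compound 2 to compound 3 thus cannot be read in size, because of the limit of > 100000 nM in this assay, at which 3 of the 3 values shown sit. Compound 4 `COc1cc(NC(=O)c2csc(-c3cn(Cc4ccc(Cl)cc4)c4ccccc34)n2)cc(OC)c1OC` differs from compound 2 by 3,4,5-trimethoxyphenyl in place of phenyl on an amide-type nitrogen. Among the compounds with values here, none of the measured steps resembles this change, and the three values give no direction at all, since each is only a limit. Compound 4 is therefore expected to show a number no higher from compound 2 to compound 4 (the limit leaves the size open), most likely staying at the limit itself. The estimate for compound 4 is 100000 nM, with an expected range from 20000 nM to 300000 nM.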

Compound 4, half-maximal inhibitory concentration: > 100000 nM
Compound 4: only a limit was reported; the forecaster's own chance of this, stated with the estimate: 70%; the middle value sits exactly at the limit.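

In this assay compound 4 gives > 100000 nM, which is a limit and not a number. Its steps from compound 1 and compound 2 therefore cannot be read in size: the limit of > 100000 nM in this assay, at which 4 of the 4 values shown sit. The compounds shown leave open what change, if any, would give a readable number in this assay.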